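Aryl amine variation on a shared core, growth inhibition

The source may hold more compounds than are shown below. What is called first, only, known or untested is meant among the compounds shown, and "the series" means these compounds.

Compound 1 `CC(C)CCn1cnc2c(Nc3cccc(O)c3)nc(N[C@H]3CC[C@H](N)CC3)nc21` carries a 3-hydroxyphenyl on a nitrogen on an aromatic ring of the shared core; in a functional assay on HCC827 cells (Homo sapiens) for inhibition, read by fluorescence, with a stated time of 72 h (on this read-out higher numbers stand for weaker inhibition of growth and lower numbers for stronger inhibition of growth), compound 1 gives 21300 nM. Among the three measured compounds, compound 1 stands second highest, within the scatter of both neighbours. Compound 3 `N[C@H]1CC[C@H](Nc2nc(Nc3ccc(O)cc3)c3ncn(C4CCCCC4)c3n2)CC1` gives 32500 nM, and compound 2 `CC(C)=CCn1cnc2c(Nc3cccc(Cl)c3)nc(N[C@H]3CC[C@H](N)CC3)nc21` gives 13500 nM; no two of the three are separated beyond the scatter. Compound 4 `COc1cc(Nc2nc(N[C@H]3CC[C@H](N)CC3)nc3c2ncn3CCC(C)C)cc(OC)c1` is not yet measured. Its change from compound 1 is 3,5-dimethoxyphenyl in place of 3-hydroxyphenyl on a nitrogen on an aromatic ring. For the measured compounds named here, no measured pair isolates this change, so the data give no size or direction for it; the expected step in this assay is none beyond the scatter. Compound 4 is expected to give 16000 nM (range 5000 nM to 50000 nM), an estimated step of a 1.3-fold lower number from compound 1 to compound 4 (0.12 log units; within the scatter).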

Compound 4, concentration for 50% growth inhibition: 11200 nM
Compound 4: the middle estimate sits 1.4-fold (0.15 log units) above what was measured; measured number inside the range.
By their numbers in this assay, from the lowest: compounds 4, 2, 1 and 3 (each within the scatter of the next, the first and the last beyond it).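

In this assay, 3,5-dimethoxyphenyl in place of 3-hydroxyphenyl on a nitrogen on an aromatic ring gives a 1.9-fold lower number from compound 1 to compound 4 (0.28 log units; within the scatter) and so provides the first step measured at this position. At this position, this exchange of groups does not move the number beyond the scatter. Nothing on hand explains the size of this step. As far as these compounds go, whether a single methoxy, an amine or a carboxylic acid on the phenyl ring would give a step beyond the scatter remains open. Also open, from the compounds shown here alone, is whether this exchange gives a similar step when other parts of the shared core differ.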